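The source may report more compounds than this note shows. Statements on the series, on what has been measured and on what is new or still open speak of the compounds shown alone.

In a functional assay on MCF7 cells (Homo sapiens) for antiproliferative activity (a lower number here means a stronger inhibitor, a higher number a weaker inhibitor), compound 1 `CON(C)C(=O)[C@H]1CC=C(CCC=C(C)C)C[C@@H]1c1ccccc1` gives 42100 nM and compound 2 `CC(C)=CCCC1=CC[C@H](C(=O)NO)[C@@H](c2ccccc2)C1` gives 72300 nM. These two values lie within the scatter of each other, so compound 1 holds no distinct rank. Compound 3 `CC(C)=CCCC1=CC[C@H](C(=O)O)[C@@H](c2ccccc2)C1` remains unmeasured and carries hydroxy in place of methoxy(methyl)amino on a carbonyl carbon. For the measured compounds named here, the only measured step at this place, a 1.7-fold higher number from compound 1 to compound 2 (0.23 log units; within the scatter), stayed within the scatter, so no change beyond the scatter is expected in this assay. Compound 3 is estimated at 60000 nM, with an expected range of 25000 nM to 140000 nM, which gives an expected 1.4-fold higher number from compound 1 to compound 3 (0.15 log units; within the scatter).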

Compound 3, half-maximal inhibitory concentration: 64300 nM
Beside the measured number, compound 3's estimate is 1.1-fold (0.03 log units) below it, and the stated range covers the measured number.
By their numbers in this assay, from the lowest: compounds 1, 3 and 2 (each within the scatter of the next).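

In this assay, the hydroxy group gives a 1.5-fold higher number from compound 1 to compound 3 (0.18 log units; within the scatter) and, set against the hydroxyamino group, a 1.1-fold lower number from compound 2 to compound 3 (0.05 log units; within the scatter). A third group on this carbonyl carbon thus also stays within the scatter, so the free carboxy reads the same as both the methoxy(methyl)carbamoyl group and the hydroxyamino-bearing carbonyl in this assay. No available evidence bears on why these values sit together. From the compounds shown here alone, it remains open whether a methyl ester or a primary amide at this place would also stay within the scatter, or whether any group on this carbonyl carbon can move the number beyond it.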